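A few compounds are considered here, and "the series" means these few. Any claim that something is new, unique, unknown or untested is made for them only; others in the source may bear on it.

Compound 1 `CCC(=O)Oc1ccc2oc(/C=C/[S+](C)[O-])cc(=O)c2c1` was measured in a functional assay on A549 cells (Homo sapiens) for cytotoxicity, with a stated time of 48 h (a lower number here means a stronger inhibitor, a higher number a weaker inhibitor), where compound 1 gives 2400 nM. Two further compounds on the same core were also measured: in this assay compound 2 `Cc1cccc2c(=O)cc(/C=C/[S+](C)[O-])oc12` gives 1700 nM, and compound 3 `COc1cccc2oc(/C=C/[S+](C)[O-])cc(=O)c12` gives 3800 nM. Compound 1 stands second highest of these three numbers, with compound 2 nearest and compound 3 furthest, both gaps lying within the usual scatter. The account now turns to compound 4 `CC(C)Oc1ccc2oc(/C=C/[S+](C)[O-])cc(=O)c2c1`, which differs from compound 1 in one place: isopropyl in place of propanoyl on an oxygen on an aromatic ring. Among the compounds with values here, no comparable step between measured compounds exists, so the size of this change is unknown; a step of no more than the scatter, in either direction, is expected in this assay. On that basis compound 4 is expected to give about 2800 nM, within a range from 1000 nM to 8000 nM. The expected step of a 1.2-fold higher number from compound 1 to compound 4 (0.07 log units; within the scatter) is therefore small.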

Compound 4, half-maximal inhibitory concentration: 1500 nM
Compound 4: the middle estimate sits 1.9-fold (0.27 log units) above what was measured; the measured number falls inside the stated range.
By their numbers in this assay, from the lowest: compounds 4, 2, 1 and 3 (each within the scatter of the next, the first and the last beyond it).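

In this assay the exchange of propanoyl for isopropyl on an oxygen on an aromatic ring gives a 1.6-fold lower number from compound 1 to compound 4 (0.20 log units; within the scatter). This oxygen can therefore carry a group with no double bond and no hydrogen-bond acceptor in place of one that has both, without a step beyond the scatter. No measurement here explains this result. Going by these compounds, it remains open whether a longer chain, or a chain ending in an amine or a carboxylic acid, on this oxygen would move the number beyond the scatter.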